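This account rests on a few compounds, and the source may have more. Where it says the series, first, only, none or still open, it means among the compounds named here.

Compound 1 `COC(=O)c1cc(-c2cccc(NC(=O)c3ccc(/C=C/C(=O)c4ccc(C)c([N+](=O)[O-])c4)cc3)c2)on1` is the starting point of this step. In an ADME assay on Vero cells (Chlorocebus sabaeus) for cytotoxicity, read by MTT assay, with a stated time of 72 h (on this read-out lower numbers stand for higher toxicity in this test and higher numbers for lower toxicity in this test), compound 1 gives > 80 ug/mL, which is a limit of the assay rather than a number (the limit of > 80 ug/mL in this assay, at which 1 of the 2 values shown sits). Within the data shown here, the only other measured compound, compound 2 `O=C(O)c1ccc(/C=C/C(=O)c2ccc(Cl)cc2)cc1`, shares the double-bonded chain carbon and the attached carbonyl with compound 1 but carries a different substituent pattern and a carboxylic acid. In this assay compound 2 gives < 10 ug/mL, again a limit and not a number (the limit of < 10 ug/mL in this assay, at which 1 of the 2 values shown sits). Compound 3 `COC(=O)c1cc(-c2cccc(NC(=O)c3ccc(/C=C/C(=O)c4cccc(F)c4)cc3)c2)on1` differs from compound 1 in one place: 3-fluorophenyl in place of 4-methyl-3-nitrophenyl on a carbonyl carbon. Among the measured compounds shown here, no measured pair of compounds carries this same change, so the size of the step can only be expected, and the expectation is that it stays within the scatter, a number no higher from compound 1 to compound 3 (the limit leaves the size open). On that basis compound 3 is estimated to give 80 ug/mL in this assay, with a range from 40 ug/mL to 160 ug/mL.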

Compound 3, half-maximal cytotoxic concentration: > 40 ug/mL
Compound 3: only a limit was reported (the forecaster's own chance of this, stated with the estimate: 65%); the middle value is on the limit's open side.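

Compound 1 and compound 3 are both reported only as limits of the assay, and no step can be read between them. The compounds shown leave open how far, and in which direction, 3-fluorophenyl in place of 4-methyl-3-nitrophenyl shifts the half-maximal cytotoxic concentration.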